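The source may report more compounds than this note shows. Statements on the series, on what has been measured and on what is new or still open speak of the compounds shown alone.

Measured so far:
- compound 1 `CO[C@@H]1CC=C2NN(c3ccc(Cl)cc3)C(=O)C[C@]2(C)O1` gives 24200 nM in a functional assay on DU-145 cells (Homo sapiens) for inhibition, read by sulforhodamine B assay, with a stated time of 48 h; a lower number here means a stronger inhibitor, a higher number a weaker inhibitor
- compound 2 `CO[C@@H]1CC=C2NN(c3cc(Cl)cc(Cl)c3)C(=O)C[C@]2(c2ccncc2)O1` gives 7600 nM in this assay

Compound 1 holds the highest of the two numbers; compound 2 lies below it by more than the usual scatter, but the two differ in more than one place, so no single step can be read from that pair.

The next compound, compound 3 `CO[C@@H]1CC=C2NN(c3cccnc3)C(=O)C[C@]2(C)O1`, differs from compound 1 in one place only: pyridin-3-yl in place of 4-chlorophenyl on an amide-type nitrogen in a ring. Within the data shown here, no measured pair shows what this exchange does on this core, so the expectation rests on compound 1 alone. The step is expected to be small, toward a weaker inhibitor, and it may well remain within the scatter; the expected step is a 1.7-fold higher number from compound 1 to compound 3 (0.22 log units; within the scatter). For compound 3 the estimated value in this assay is 40000 nM, with a range from 12000 nM to 130000 nM.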

Compound 3, half-maximal inhibitory concentration: 16400 nM
Estimate against measurement, compound 3: 2.4-fold (0.39 log units) above, within the range that was stated.
By their numbers in this assay, from the lowest: compound 2; then compounds 3 and 1 (each within the scatter of the next).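

In this assay, among these compounds, the exchange of 4-chlorophenyl for pyridin-3-yl on the amide-type nitrogen in a ring gives a 1.5-fold lower number from compound 1 to compound 3 (0.17 log units; within the scatter) and so provides the first single-place comparison. On the core of compound 1, this position therefore shows no change beyond the scatter when the chlorine leaves and a ring nitrogen, counted as one hydrogen-bond acceptor, enters the six-membered aromatic ring. No supporting measurement is available to explain this result.

Still open, on these data alone, is how this position responds to groups of another kind, such as an amine or a carboxylic acid on the aromatic ring, or a longer chain in place of that ring. As far as these compounds go, it is also open whether the same exchange gives a similar step on the core of compound 2.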